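The source may report more compounds than this note shows. Statements on the series, on what has been measured and on what is new or still open speak of the compounds shown alone.

Two compounds carry measured numbers here. Compound 1, `Nc1nc(O)c2c(n1)n(C1OC(CO)[C@@H](O)[C@H]1O)c(=O)n2C/C=C/c1ccccc1`, stands highest of the two in a functional assay on the whole organism with Mus musculus as the target (on this read-out higher numbers stand for larger maximal responses and lower numbers for smaller maximal responses), where compound 1 reaches 5%. Compound 2, `CCCn1c(=O)n(C2CCC(CO)O2)c2nc(NC(=O)C(C)(C)C)nc(O)c21`, is its nearest neighbour: in this assay compound 2 reaches 4%, and the gap between the two lies within the usual scatter, so neither can be placed above the other. Both maximal responses are small. The unmeasured compound 3, `CCCCn1c(=O)n(C2OC(CO)[C@@H](O)[C@H]2O)c2nc(N)nc(O)c21`, shares the core of compound 1 and differs from it in one place: propyl in place of 2-phenylethenyl on a saturated chain carbon bound to an aromatic nitrogen. Going by the values given here, no step between two measured compounds exists for this exchange, and compound 2 is not a single-change partner of either; its value shows only that a small maximal response is reached there as well. Compound 3 is expected to remain in the same low region, because compound 1 gives 5% in this assay. The step of no change at the digits printed from compound 1 to compound 3 (within the scatter) is expected to be none beyond the scatter. Compound 3 is therefore estimated at 5% in this assay, with a range from 0% to 15%.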

Compound 3, largest response reached (reported as maximal response), in percent of the reference or control that the assay uses: 70%
Compound 3: middle estimate off by 65 percentage points, on the low side; measured number above the stated range.
By their numbers in this assay, from the lowest: compounds 2 and 1 (each within the scatter of the next); then compound 3.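

At this position, on a saturated chain carbon bound to an aromatic nitrogen, the exchange of 2-phenylethenyl for propyl gives in this assay a step of a number 65 percentage points higher from compound 1 to compound 3 (beyond the scatter), the first difference in this small set that lies beyond the scatter. The shared core therefore does not by itself hold the maximal response at a low level: with that core unchanged, the group at this one place decides between a small and a large response. The change removes a six-membered aromatic ring of carbon only and a double bond outside aromatic rings, and it takes the group from 8 heavy atoms to 3 heavy atoms, but nothing available shows which of these differences accounts for the step or why it arises.

On these data alone, what stays open is whether the ring, the double bond or the chain length carries the step, a question that a saturated 3-phenylpropyl group or a shorter ethyl group at this place would separate. As far as these compounds go, it is equally open how far the response holds with a longer chain such as hexyl, or with an amine at the end of the chain.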